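Fluoro to methoxy on compound 2

A few compounds are considered here, and "the series" means these few. Any claim that something is new, unique, unknown or untested is made for them only; others in the source may bear on it.

Measured in a functional assay on A549 cells (Homo sapiens) for antiproliferative activity, read by MTT assay, with a stated time of 48 h; on this read-out lower numbers stand for stronger inhibition and higher numbers for weaker inhibition:
compound 1 `Fc1ccc(-c2nn(-c3ccccc3)cc2-c2nc3cc(Br)ccc3[nH]2)cc1`: 5830 nM
compound 2 `COc1ccc2[nH]c(-c3cn(-c4ccccc4)nc3-c3ccc(F)cc3)nc2c1`: 1960 nM
compound 3 `Fc1ccc(-c2nn(-c3ccccc3)cc2-c2nc3cc(C(F)(F)F)ccc3[nH]2)cc1`: 2340 nM

Compound 2 stands clear of one measured neighbour and level with the other: a 3.0-fold lower number from compound 1 to compound 2 (0.47 log units; beyond the scatter), while a 1.2-fold higher number from compound 2 to compound 3 (0.08 log units; within the scatter). Compound 4 `COc1ccc(-c2nn(-c3ccccc3)cc2-c2nc3cc(OC)ccc3[nH]2)cc1` differs from it at another site, with methoxy in place of fluoro on an aromatic carbon, 4-fluorophenyl to 4-methoxyphenyl: methoxy in place of fluoro on an aromatic carbon. For the measured compounds named here, no measured step touches this site. The measured steps concern only the group varied among the first three compounds, and they stay small, as in a 2.5-fold lower number from compound 1 to compound 3 (0.40 log units; beyond the scatter). They offer only a weak guide, so no firm direction can be expected. The expected step is a 1.3-fold higher number from compound 2 to compound 4 (0.11 log units; within the scatter). Compound 4 is estimated at 2500 nM, with an expected range of 1000 nM to 6000 nM.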

Compound 4, half-maximal inhibitory concentration: 22700 nM
Estimate against measurement, compound 4: 9.1-fold (0.96 log units) below, and the stated range ends below it.
By their numbers in this assay, from the lowest: compounds 2 and 3 (each within the scatter of the next); then compound 1; then compound 4.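

In this assay, for the compounds shown here, the 4-fluorophenyl position proves far more sensitive than the earlier compounds could suggest: methoxy in place of fluoro gives a 12-fold higher number from compound 2 to compound 4 (1.06 log units; beyond the scatter) in a single change. This exceeds the largest step at the site varied among the first three compounds, which is a 3.0-fold lower number from compound 1 to compound 2 (0.47 log units; beyond the scatter) and runs the other way, towards lower numbers. Nothing measured here explains the loss. From the compounds shown here alone, whether the loss follows methoxy alone stays open: a chloro or methyl group at this place could stay level with compound 2 or climb towards compound 4.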